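Pyridin-3-yl in place of a halogenated phenyl

This account rests on a few compounds, and the source may have more. Where it says the series, first, only, none or still open, it means among the compounds named here.

Measured compounds:
compound 1 `CCCCCc1cc(C(F)(F)F)ccc1CNC(=O)C(C)c1ccc(NS(C)(=O)=O)c(F)c1`: 0.4 nM
compound 2 `CC(C(=O)NCc1ccc(C(F)(F)F)cc1-c1ccc(F)c(Cl)c1)c1ccc(NS(C)(=O)=O)c(F)c1`: 0.6 nM

In an assay on CHO cells for antagonist activity at transient receptor potential cation channel subfamily V member 1 (Homo sapiens), read by FLIPR (a lower number here means a stronger inhibitor, a higher number a weaker inhibitor), compound 2 gives 0.6 nM, the highest of the two numbers, and the step of a 1.5-fold higher number from compound 1 to compound 2 (0.18 log units; within the scatter) lies within the scatter. Compound 3 `CC(C(=O)NCc1ccc(C(F)(F)F)cc1-c1cccnc1)c1ccc(NS(C)(=O)=O)c(F)c1` differs from compound 2 by pyridin-3-yl in place of 3-chloro-4-fluorophenyl on an aromatic carbon. Going by the values given here, no measured step covers an exchange of this kind; the only step known, a 1.5-fold higher number from compound 1 to compound 2 (0.18 log units; within the scatter), concerns a different group and was small. Compound 3 is therefore expected to stay close to compound 2, with a modest step of a 2.0-fold higher number from compound 2 to compound 3 (0.30 log units; within the scatter). The estimate for compound 3 is 1.2 nM, with a range from 0.4 nM to 4 nM.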

Compound 3, inhibition constant: 59.4 nM
Compound 3: middle estimate off by 50-fold (1.69 log units), on the low side, and the stated range ends below it.
By their numbers in this assay, from the lowest: compounds 1 and 2 (each within the scatter of the next); then compound 3.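

In this assay, this position proves sensitive to the group it carries: pentyl and 3-chloro-4-fluorophenyl stood within the scatter of each other, but pyridin-3-yl brings (a 99-fold higher number from compound 2 to compound 3 (2.00 log units; beyond the scatter)) and (a 150-fold higher number from compound 1 to compound 3 (2.17 log units; beyond the scatter)). The tolerance seen with the first two groups therefore does not extend to every six-membered aromatic ring placed here. Nothing available explains this loss. The compounds shown leave open whether it follows the ring nitrogen or the departure of chlorine and fluorine, since these change together. Going by these compounds, how a plain phenyl or a pyridin-4-yl would fare here also remains open.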